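The source may hold more compounds than are shown below. What is called first, only, known or untested is meant among the compounds shown, and "the series" means these compounds.

Measured so far in a functional assay on MKN-45 cells (Homo sapiens) for inhibition, with a stated time of 72 h; on this read-out higher numbers stand for weaker inhibition and lower numbers for stronger inhibition:

- compound 1 `COc1ccc(S(=O)(=O)N2CCc3cccc(-c4ccc([N+](=O)[O-])cc4)c32)cc1`: 34 nM
- compound 2 `COc1ccc(S(=O)(=O)N2CCc3cccc(-c4ccc(O)cc4)c32)cc1`: 82.6 nM

Compound 2 has the higher number of the two, which makes it the weaker inhibitor of this pair. The next compound, compound 3 `COc1ccc(S(=O)(=O)N2CCc3cccc(-c4cccs4)c32)cc1`, carries thiophen-2-yl in place of 4-hydroxyphenyl on an aromatic carbon of the shared core, and the exchange counts as follows: thiophen-2-yl in place of 4-hydroxyphenyl on an aromatic carbon. Among the compounds with values here, no measured compound carries thiophen-2-yl, so the data offer no direct comparison. Within the data shown here, only one measured step bears on the change, and only indirectly. Putting hydroxy in place of nitro on an aromatic carbon gave a 2.4-fold higher number from compound 1 to compound 2 (0.39 log units; beyond the scatter), a modest step. Compound 3, like compound 1, has no hydroxy group. On that slim evidence, this assay is expected to show a step no larger than that modest one, leaning towards a lower number, and it may stay within the scatter. The estimated step is a 1.5-fold lower number from compound 2 to compound 3 (0.18 log units; within the scatter), with wide uncertainty. For compound 3 the expected value is 55 nM, within an estimated range from 18 nM to 170 nM.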

Compound 3, half-maximal inhibitory concentration: 165 nM
Beside the measured number, compound 3's estimate is 3.0-fold (0.48 log units) below it, within the range that was stated.
By their numbers in this assay, from the lowest: compound 1; then compounds 2 and 3 (each within the scatter of the next).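

In this assay, within the data shown here, the aromatic carbon of the shared core still gives a measurable number when a five-membered aromatic ring with one hetero atom replaces a six-membered aromatic ring of carbon only: thiophen-2-yl in place of 4-hydroxyphenyl gives a 2.0-fold higher number from compound 2 to compound 3 (0.30 log units; within the scatter), so removing the hydroxy group and changing the ring together produce no step that stands clear of the usual variation. The same exchange made against 4-nitrophenyl gives a 4.9-fold higher number from compound 1 to compound 3 (0.69 log units; beyond the scatter), a step that does stand clear, which leaves compound 1 as the strongest inhibitor of the three. Nothing available here explains why the two exchanges differ in size.

The compounds shown leave open how an unsubstituted phenyl ring would compare, and such a compound would help separate the change of ring from the loss of the nitro or hydroxy group. Also open, as far as these compounds go, is how the number would respond to an amine or a carboxylic acid in place of nitro on the phenyl ring.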